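Furan-2-yl to 4-Sulfamoylphenyl on a Shared Core

The source may report more compounds than this note shows. Statements on the series, on what has been measured and on what is new or still open speak of the compounds shown alone.

Compound 2 `O=C(O)Cc1sc(C(c2ccc(F)cc2)c2ccc(F)cc2)nc1-c1ccco1` was tested in an in vitro functional assay on HEK285-7 cells for antagonist activity at prostaglandin D2 receptor 2 (Homo sapiens), read by BRET and beta-arrestin recruitment (a lower number here means a smaller maximal response, a higher number a larger maximal response), where compound 2 gives 80%. Compound 1 `N#Cc1cc(-c2nc(C(c3ccc(F)cc3)c3ccc(F)cc3)sc2CC(=O)O)ccc1F` gives 80% in this assay, and compound 3 `O=C(O)Cc1sc(C(c2ccccc2)c2ccccc2)nc1-c1ccc(C(F)(F)F)cc1` gives 80% in this assay; compound 2 stands level with both of them, within the scatter. For the measured compounds named here, the single measured step, no change at the digits printed from compound 1 to compound 2 (within the scatter), exchanges one aromatic group on the shared core for another. Compound 4 `NS(=O)(=O)c1ccc(-c2nc(C(c3ccc(F)cc3)c3ccc(F)cc3)sc2CC(=O)O)cc1` differs from compound 2 in the same position: 4-sulfamoylphenyl in place of furan-2-yl on an aromatic carbon. Going by the values given here, only that one measured step bears on this change, and it stayed within the scatter, so no step beyond the scatter is expected in this assay, no change at the digits printed from compound 2 to compound 4 (within the scatter). Compound 4 is therefore estimated to give 80% in this assay, within a range from 65% to 95%.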

Compound 4, largest response reached (reported as efficacy), in percent of the reference or control that the assay uses: 80%
Estimate against measurement, compound 4: no gap at the digits printed; low and high end bracket the measured number.
By their numbers in this assay, from the lowest: compounds 1, 2, 3 and 4 (each within the scatter of the next).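

In this assay, 4-sulfamoylphenyl in place of furan-2-yl gives no change at the digits printed from compound 2 to compound 4 (within the scatter), and 4-sulfamoylphenyl in place of 3-cyano-4-fluorophenyl gives no change at the digits printed from compound 1 to compound 4 (within the scatter). This position therefore accepts a six-membered aromatic ring bearing a sulfamoyl group, with its hydrogen-bond donor, with no step beyond the scatter from either furan-2-yl or 3-cyano-4-fluorophenyl. Nothing available here explains why the response stays level. Every group shown at this position is aromatic, so it remains open whether a non-aromatic group, such as a piperidine or a propyl chain, would hold the same level. As far as these compounds go, whether a primary amine on the phenyl ring would do so also remains open.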